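The compounds below may be only part of what the source reports. "The series", "measured", "known", "first", "only" and "open" are said of these compounds alone.

Compound 1 `CCOC(=O)OCOC(=O)C1=C(S[C@@H]2CN[C@H](C(=O)Nc3cccc(C(=O)O)c3)C2)[C@H](C)[C@@H]2[C@@H]([C@@H](C)O)C(=O)N12`, compound 2 `CC(C)OC(=O)c1cccc(NC(=O)[C@@H]2C[C@H](SC3=C(C(=O)O)N4C(=O)[C@H]([C@@H](C)O)[C@H]4[C@H]3C)CN2)c1` and compound 3 `COC(=O)OCOC(=O)C1=C(S[C@@H]2CN[C@H](C(=O)Nc3cccc(C(=O)O)c3)C2)[C@H](C)[C@@H]2[C@@H]([C@@H](C)O)C(=O)N12` have been run in a physicochemical assay for metabolic stability, read by LC-MS, in phosphate buffer, with a stated time of 3 h, at pH 7.4, tested at 50 uM; a lower number here means that less of the compound is left, a higher number that more of the compound is left; compound 4 `CCOC(=O)c1cccc(NC(=O)[C@@H]2C[C@H](SC3=C(C(=O)O)N4C(=O)[C@H]([C@@H](C)O)[C@H]4[C@H]3C)CN2)c1` has not. In this assay compound 1 gives > 95%, which is a limit of the assay and not a number. Compound 3 gives > 95%, likewise a limit. Compound 2 gives > 95%, also a limit. The difference between the core of compound 1 and the core of compound 2 is not broken down here. From compound 1 to compound 3 the change is hydrogen in place of methyl on a saturated chain carbon bound to an oxygen next to a carbonyl group, and the step is a step that the two limits leave unreadable from compound 1 to compound 3; both ends sit at the limit of > 95% in this assay, at which 3 of the 3 values shown sit. From compound 2 to compound 4 the same kind of change is made, (hydrogen in place of methyl on a saturated chain carbon bound to an oxygen next to a carbonyl group and a saturated chain carbon), the place here also bound to a saturated chain carbon. Compound 4 is expected to show a step that the limit leaves unreadable from compound 2 to compound 4 because all values shown sit at the limit of > 95% in this assay, at which 3 of the 3 values shown sit. The estimate for compound 4 in this assay is 97%.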

Compound 4, percent of the compound remaining: > 95%
Compound 4: only a limit was reported; the forecaster's own chance of this, stated with the estimate: 85%; the middle value lies beyond the limit too.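

No step can be read from compound 2 to compound 4, because both values are limits of the assay: the limit of > 95% in this assay, at which 4 of the 4 values shown sit.

The compounds shown leave open how far isopropoxycarbonyl and ethoxycarbonyl differ in the percent of compound remaining.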